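This account rests on a few compounds, and the source may have more. Where it says the series, first, only, none or still open, it means among the compounds named here.

Compound 1 `Oc1ccc(-c2cc(-c3ccccn3)nc(-c3ccccc3Cl)c2)cc1`: "not determined" (no result reported) in an assay on isolated protein for inhibition of DNA topoisomerase 1 (Homo sapiens), with a stated time of 30 min, tested at 20 uM; on this read-out lower numbers stand for a weaker effect and higher numbers for a stronger effect at the one concentration tested.
Compound 2 `Oc1ccc(-c2cc(-c3cccc(Cl)c3)nc(-c3ccccn3)c2)cc1`: 0% in this assay.
Compound 3 `Oc1cccc(-c2cc(-c3cccc(Cl)c3)nc(-c3ccccn3)c2)c1`: "not determined" (no result reported) in this assay.

Compound 2 carries the only number shown in this assay; for compound 1 and compound 3 nothing was determined, so no step between measured compounds can be drawn and compound 2 stands alone, at the floor of the read-out. Compound 4 `Oc1ccc(-c2cc(-c3cccnc3)nc(-c3cccc(Cl)c3)c2)cc1` is the next entry. It differs from compound 2 in one place: pyridin-3-yl in place of pyridin-2-yl on an aromatic carbon. The two share every atom and differ only in how these are joined.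

Among the measured compounds shown here, no measured step is available against which this change could be weighed. Compound 2 shows no measurable inhibition in this assay, and the exchange of pyridin-2-yl for pyridin-3-yl gives no ground, on these data alone, to expect a shift beyond the scatter. The step from compound 2 to compound 4 is therefore estimated as a number 3 percentage points higher from compound 2 to compound 4 (within the scatter), that is, none beyond the scatter in either direction. For compound 4 the expected value in this assay is 3%, with a range from 0% to 15%.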

Compound 4, a percentage reported as inhibition, at one concentration (the size of the read-out at that concentration, not a potency): 0%
For compound 4 the middle estimate is 3 percentage points above the measured one, within the range that was stated.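

In this assay, among the compounds shown here, pyridin-3-yl in place of pyridin-2-yl on this aromatic carbon, next to the ring nitrogen, gives no change at the digits printed from compound 2 to compound 4 (within the scatter), the first step that can be read. Compound 2 and compound 4 both lie at the bottom of the read-out, so neither pyridine isomer shows measurable inhibition at the one concentration tested, and moving the ring nitrogen in this group does not by itself bring out an effect. Two values at the bottom of the read-out cannot show whether either isomer lies closer to activity, and no measurement at hand offers an explanation for the lack of effect.

Going by these compounds, it remains open whether an amine or a carboxylic acid on the pyridine ring, or in place of the chlorine on the 3-chlorophenyl group, would give any inhibition in this assay. On these data alone, it also remains open whether the place of the pyridine nitrogen would matter on a core with a value clear of the bottom of the read-out.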